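Hydroxamic acid aminopyrimidines: aryl amine swapped for cyclopropyl

The source may report more compounds than this note shows. Statements on the series, on what has been measured and on what is new or still open speak of the compounds shown alone.

Compound 1 `O=C(CCCCCn1cc(Nc2ncc(Cl)c(Nc3ccccc3Cl)n2)cn1)NO`: 630 nM
Compound 2 `O=C(CCCCCCn1cc(Nc2ncc(Cl)c(Nc3ccc(F)cc3)n2)cn1)NO`: 220 nM
Compound 3 `O=C(/C=C/c1ccc(Cn2cc(Nc3ncc(Cl)c(Nc4ccc(F)cc4)n3)cn2)cc1)NO`: 330 nM

Of the compounds shown here, three have been tested in a functional assay on MOLT-4 cells (Homo sapiens) for antiproliferative activity, read by MTT assay, with a stated time of 48 h; a lower number here means a stronger inhibitor, a higher number a weaker inhibitor. Compound 2 shows the lowest number of the three, but its gap to compound 3 lies within the scatter, so only compound 1 stands clearly apart from it. Compound 4 `O=C(CCCCCCn1cc(Nc2ncc(Cl)c(NC3CC3)n2)cn1)NO` has not yet been measured. It differs from compound 2 in one place: cyclopropyl in place of 4-fluorophenyl on a nitrogen on an aromatic ring. Among the measured compounds shown here, no measured pair shows this kind of change, so its effect cannot be read from the data. A modestly weaker result is expected for compound 4, with a step of a 2.3-fold higher number from compound 2 to compound 4 (0.36 log units; beyond the scatter) that may or may not exceed the scatter. The estimate for compound 4 is 500 nM, within a range from 200 nM to 1500 nM.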

Compound 4, half-maximal inhibitory concentration: 150 nM
Beside the measured number, compound 4's estimate is 3.3-fold (0.52 log units) above it, outside the stated range (below it).
By their numbers in this assay, from the lowest: compounds 4, 2, 3 and 1 (each within the scatter of the next, the first and the last beyond it).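

In this assay, among the compounds shown here, cyclopropyl in place of 4-fluorophenyl on a nitrogen on an aromatic ring gives a 1.5-fold lower number from compound 2 to compound 4 (0.17 log units; within the scatter) and is the first single-place comparison. At this position, then, the six-membered aromatic ring can give way to a three-membered non-aromatic ring with 3 heavy atoms instead of 7, without a change beyond the scatter. Nothing shown gives a cause for this result. Going by these compounds, whether a smaller group such as methyl, or a cyclic amine such as morpholine, would fare alike on that nitrogen remains open. So does whether the same swap would read alike on compound 3 .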